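Replacing the Oxime Hydroxyl With a Carbamate Group

The source may report more compounds than this note shows. Statements on the series, on what has been measured and on what is new or still open speak of the compounds shown alone.

All three measured compounds were tested in a functional assay (blood) for inhibition, with Homo sapiens as the target; a lower number here means a stronger inhibitor, a higher number a weaker inhibitor. Compound 1 `CO[C@]1(c2cnc(Sc3ccc(/C(C)=N/O)cc3)s2)CCO[C@@H](C)C1` gives 40 nM. Compound 3 `CO[C@]1(c2cc(F)cc(S(=O)(=O)c3ccc(/C(C)=N/OCC#N)cc3)c2)CCO[C@@H](C)C1` gives 60 nM. Compound 2 `O/N=C/c1ccc(Sc2cc(F)cc(C3CCOCC3)c2)cc1` gives 120 nM, the highest of the three numbers; its gap to compound 3 lies within the usual scatter of repeated measurements, while its gap to compound 1 lies beyond it.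

Compound 4 `C/C(=N\OC(=O)N(C)C)c1ccc(Sc2cc(F)cc(C3CCOCC3)c2)cc1` is not yet measured. It differs from compound 2 in one place: a group of 9 heavy atoms (5 carbon, 2 nitrogen, 2 oxygen; no ring) in place of a group of 3 heavy atoms (1 carbon, 1 nitrogen, 1 oxygen; no ring), on an aromatic carbon. The entering group keeps the oxime of compound 2 but replaces its free hydroxyl with an attached carbamate. Compound 3, which also carries an attached group on the oxime oxygen, gives 60 nM, and compound 1 with a plain ketoxime gives 40 nM, so such variation at this place has so far gone with low numbers. The step of a 1.5-fold lower number from compound 2 to compound 4 (0.18 log units; within the scatter) is therefore expected to be small, toward a lower number, and close to the scatter. Compound 4 is estimated at 80 nM, within a range from 25 nM to 250 nM.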

Compound 4, half-maximal inhibitory concentration: 2610 nM
Compound 4: the middle estimate sits 33-fold (1.51 log units) below what was measured; measured number outside the range, above it.
By their numbers in this assay, from the lowest: compounds 1, 3 and 2 (each within the scatter of the next, the first and the last beyond it); then compound 4.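

In this assay, among these compounds, this position proves far less forgiving than the earlier compounds suggested: the change brings a 22-fold higher number from compound 2 to compound 4 (1.34 log units; beyond the scatter), which means a much weaker inhibitor and a step beyond the scatter. The free hydroxyl of the oxime cannot simply be capped with a carbamate on this core without a large loss, as the entering group has 0 hydrogen-bond donors and 9 heavy atoms where the leaving group has 1 donor and 3 heavy atoms. No measurement shown explains this loss. The step joins the carbamate and a methyl on the oxime carbon, so the compounds shown leave open which of the two goes with the higher number. Also open, going by these compounds, is how a methyl ether or an acetyl on the oxime oxygen, or an amine in place of the oxime, would fare on this core.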